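A few compounds are considered here, and "the series" means these few. Any claim that something is new, unique, unknown or untested is made for them only; others in the source may bear on it.

Working notes on the thienopyrimidine-type urea series, step from compound 2 to compound 4.

For the measured compounds named here, in a functional assay on LNCaP cells (Homo sapiens) for cytotoxicity (on this read-out higher numbers stand for weaker inhibition and lower numbers for stronger inhibition), compound 2 `CN1CCN(Cc2cc3nc(-c4ccc(NC(=O)Nc5cccnc5)cc4)nc(N4CC5CCC(C4)O5)c3s2)CC1` gives 148 nM, the second highest of the three numbers measured so far. Its nearest neighbour is compound 3 `O=C(Nc1ccc(-c2nc(N3CC4CCC(C3)O4)c3sccc3n2)cc1)Nc1cccnc1`, which in this assay gives 27 nM; furthest is compound 1 `c1cc2cc(-c3nc(N4CC5CCC(C4)O5)c4sccc4n3)ccc2[nH]1`, which carries an indole in place of the aryl urea and gives 1350 nM. Going by the values given here, the only step between compounds that differ in a single place is a 5.5-fold lower number from compound 2 to compound 3 (0.74 log units; beyond the scatter), hydrogen in place of (4-methylpiperazin-1-yl)methyl on an aromatic carbon, and it touches the thiophene side, not the urea end.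

Compound 4 `CN1CCN(Cc2cc3nc(-c4ccc(NC(=O)NC5CC5)cc4)nc(N4CC5CCC(C4)O5)c3s2)CC1` keeps the (4-methylpiperazin-1-yl)methyl of compound 2 and differs only at the urea: cyclopropyl in place of pyridin-3-yl on an amide-type nitrogen. Among the compounds with values here, no measured step bears on this change. Within the data shown here, compound 1 and compound 2 differ in more than one place, so their two values show only that the indole compound sits higher; they say nothing about exchanging one urea substituent for another. With no anchor in the data, the step is expected to be a 2.7-fold higher number from compound 2 to compound 4 (0.43 log units; beyond the scatter), a modest rise in the number carrying wide uncertainty. In this assay compound 4 is estimated at 400 nM, with a range from 120 nM to 1400 nM.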

Compound 4, half-maximal inhibitory concentration: 400 nM
For compound 4 middle estimate and measured number coincide at the digits printed, within the range that was stated.
By their numbers in this assay, from the lowest: compound 3; then compound 2; then compound 4; then compound 1.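

The urea end now has its first measured single-place change: in this assay, cyclopropyl in place of pyridin-3-yl on the amide-type nitrogen gives a 2.7-fold higher number from compound 2 to compound 4 (0.43 log units; beyond the scatter), so the group on this nitrogen affects the read-out when (4-methylpiperazin-1-yl)methyl is present. The other listed change from the same parent, hydrogen in place of (4-methylpiperazin-1-yl)methyl, gives a 5.5-fold lower number from compound 2 to compound 3 (0.74 log units; beyond the scatter), so compound 2 now sits between two single-place neighbours, with the number falling in one direction and rising in the other. No measurement here explains the rise, and the data do not show which feature of pyridin-3-yl matters.

As far as these compounds go, whether the same exchange of pyridin-3-yl for cyclopropyl gives a step of similar size and direction on the core of compound 3, without the (4-methylpiperazin-1-yl)methyl group, remains open. Also open, from the compounds shown here alone, is where an open-chain ethyl or a plain phenyl on the same nitrogen would fall relative to cyclopropyl and pyridin-3-yl.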